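The source may hold more compounds than are shown below. What is called first, only, known or untested is meant among the compounds shown, and "the series" means these compounds.

Measured compounds in an assay on CHO cells for displacement of a labelled ligand from adenosine receptor A1 (Homo sapiens), with a stated time of 60 min, tested at 10 uM; on this read-out higher numbers stand for more inhibition at the one concentration tested (going by the name of the read-out) and lower numbers for less inhibition:

compound 1, `O[C@@H]1[C@H](O)CS[C@H]1Cn1cnc2c(NCc3cccc(Cl)c3)ncnc21`: 3.3%
compound 2, `O[C@@H]1[C@H](O)CS[C@H]1Cn1cnc2c(NCc3cccc(I)c3)nc(Cl)nc21`: 16.4%
compound 3, `O[C@@H]1[C@H](O)CS[C@H]1Cn1cnc2c(NCc3cccc(Br)c3)ncnc21`: 6.6%

All three numbers lie within the usual scatter of one another, so no ranking among them is claimed. Compound 3 has compound 1 as its nearest neighbour and compound 2 as its furthest, and in both cases the gap stays within the scatter; compound 2 differs from compound 3 in two places at once, so its value is only recorded alongside, not read as a step.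

Compound 4, `O[C@@H]1[C@H](O)CS[C@H]1Cn1cnc2c(NCc3cccc(I)c3)ncnc21`, is the next member, differing from compound 3 as follows: iodo in place of bromo on an aromatic carbon.

For the measured compounds named here, the one measured step that bears on this change is a number 3.3 percentage points higher from compound 1 to compound 3 (within the scatter), a swap of one halogen for a larger one on the same aromatic carbon, which did not move the read-out beyond the scatter. The step from compound 3 to compound 4 repeats the same kind of exchange one halogen further along, so no movement beyond the scatter is expected in this assay ; the expected step is a number 2.4 percentage points higher from compound 3 to compound 4 (within the scatter).

For compound 4 the estimate in this assay is 9%, with a range from 0% to 20%.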

Compound 4, a percentage reported as inhibition, at one concentration (the size of the read-out at that concentration, not a potency): 9.6%
Compound 4: the middle estimate sits 0.6 percentage points below what was measured; low and high end bracket the measured number.
By their numbers in this assay, from the lowest: compounds 1, 3, 4 and 2 (each within the scatter of the next, the first and the last beyond it).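

In this assay the change from 3-bromobenzyl to 3-iodobenzyl gives a number 3 percentage points higher from compound 3 to compound 4 (within the scatter) and the change from chloro to iodo on the same aromatic carbon gives a number 6.3 percentage points higher from compound 1 to compound 4 (within the scatter) so chloro, bromo and iodo at this place cannot be told apart on this read-out. Compound 4 also gives a single-place reading of the other chloro, on an aromatic carbon of the core: hydrogen in its place gives a number 6.8 percentage points lower from compound 2 to compound 4 (within the scatter) and so also stays inside the scatter. No supporting data bear on why these exchanges leave the read-out within the scatter.

Going by these compounds, whether a group other than a halogen at this place, such as methoxy, an amine or a carboxylic acid, would move the read-out beyond the scatter stays open. Also open, on these data alone, is whether hydrogen in place of chloro reads the same with 3-chlorobenzyl or 3-bromobenzyl.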